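This account rests on a few compounds, and the source may have more. Where it says the series, first, only, none or still open, it means among the compounds named here.

Measured compounds:
Compound 1 `O=C(CSC(=S)N[C@H]1CCOC1=O)Nc1ccccc1Cl` — in a functional assay on EC9706 cells (Homo sapiens) for cytotoxicity, read by MTT assay, with a stated time of 72 h (on this read-out higher numbers stand for weaker inhibition and lower numbers for stronger inhibition), compound 1 gives > 128000 nM, which is a limit of the assay, not a number.
Compound 2 `CSC(=S)N[C@H]1CCOC1=O` — compound 2 gives > 128000 nM, also a limit.
Compound 3 `O=C(CCl)Nc1ccc(C(=O)/C=C/c2ccc(Br)cc2)cc1` — compound 3 gives 10100 nM.

Going by the values given here, compound 3 is therefore the only compound with a measured number; the other two sit at the limit of > 128000 nM in this assay, at which 2 of the 3 values shown sit. Compound 4 `Cc1ccc(/C=C/C(=O)c2ccc(NC(=O)CCl)cc2)cc1` differs from compound 3 by methyl in place of bromo on an aromatic carbon. Among the compounds with values here, no comparable step between measured compounds exists here, so the expectation rests on the change alone: a swap of one small group for another of similar size, with no change in donors or acceptors. The expected step from compound 3 to compound 4 is small, a 1.5-fold higher number from compound 3 to compound 4 (0.17 log units; within the scatter), possibly within the scatter. Compound 4 is estimated at 15000 nM, between 5000 nM and 45000 nM.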

Compound 4, half-maximal inhibitory concentration: 7150 nM
Estimate against measurement, compound 4: 2.1-fold (0.32 log units) above, and the stated range covers the measured number.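

In this assay, going by these compounds alone, the change from 4-bromophenyl to 4-methylphenyl gives a 1.4-fold lower number from compound 3 to compound 4 (0.15 log units; within the scatter) and is the first step in this set that can be read as numbers. On an aromatic carbon para to a large group, methyl and bromo therefore cannot be told apart in this test. Nothing measured here accounts for this sameness.

As far as these compounds go, whether an amine, a carboxylic acid or a longer chain in this place would shift the value beyond the scatter stays open. A single pair also cannot say whether this swap behaves alike on another core.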